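The compounds below may be only part of what the source reports. "The series", "measured", "known", "first", "only" and "open" are said of these compounds alone.

Measured so far in an ADME assay on MRC5 cells (Homo sapiens) for cytotoxicity, read by fluorescence, with a stated time of 24 h; on this read-out higher numbers stand for weaker inhibition and lower numbers for stronger inhibition:
Compound 1 `C=CCN1C(=O)C(CC(=O)c2ccc(F)cc2)S/C1=N\N=C\c1ccccc1`: 20100 nM
Compound 2 `O=C(CC1S/C(=N\N=C\c2c(-c3ccccc3)[nH]c3ccccc23)NC1=O)c1ccccc1`: > 50000 nM

Compound 2 gives > 50000 nM, which is a limit of the assay and not a number. The position of the series at that end is short to state: the limit of > 50000 nM in this assay, at which 1 of the 2 values shown sits.

Compound 3 `CC(=O)OCCC1S/C(=N\N=C\c2c(-c3ccccc3)[nH]c3ccccc23)NC1=O` keeps the core of compound 2 and changes on a saturated chain carbon bound to a saturated ring carbon, with acetoxymethyl in place of benzoyl on a saturated chain carbon bound to a saturated ring carbon. Cut one bond further out, the same difference reads benzoylmethyl to 2-acetoxyethyl.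

For the measured compounds named here, no measured pair in this assay differs in one place only, so the size of this change has no direct precedent. Going by the values given here, the only number in hand is compound 1 at 20100 nM, and the expectation rests on it. The expectation also rests on compound 2, whose > 50000 nM is a limit of the assay. No shift beyond the scatter is expected, and any shift would most likely be towards stronger inhibition. The estimated change is an at least 1.2-fold lower number from compound 2 to compound 3 (0.09 log units; that floor lies within the scatter), and another limit reading is quite possible. In this assay the estimate for compound 3 is 40000 nM, expected to lie between 15000 nM and 60000 nM.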

Compound 3, half-maximal inhibitory concentration: 42800 nM
Estimate against measurement, compound 3: 1.1-fold (0.03 log units) below; measured number inside the range.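

In this assay, for the compounds shown here, the exchange of benzoyl for acetoxymethyl on a saturated chain carbon bound to a saturated ring carbon gives the first step that can be read: an at least 1.1-fold lower number from compound 2 to compound 3 (0.06 log units; that floor lies within the scatter), so the removal of the six-membered aromatic ring of carbon only cannot yet be called a change beyond the scatter. Going by these compounds alone, compound 3 gives 42800 nM, a measured number, which places a compound with this core on the scale of the assay for the first time. Compound 2 gives a limit of the assay, so the step has only a floor and its full size stays unknown because of that limit: the limit of > 50000 nM in this assay, at which 1 of the 3 values shown sits.

As far as these compounds go, whether the true gap from compound 2 to compound 3 exceeds the scatter stays open, as does the question of whether the ester matters at this position, which a hydroxymethyl group or a plain ethyl chain in place of acetoxymethyl would address. From the compounds shown here alone, compound 1 differs from compound 2 and compound 3 in more than one place, so it offers no comparison, and the response to an amine or a carboxylic acid on this chain remains unknown.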